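Halogen Replaces Nitro on the Triazole Benzyl Arm

The source may report more compounds than this note shows. Statements on the series, on what has been measured and on what is new or still open speak of the compounds shown alone.

Compound 2 `O=c1ccoc2cc(OCc3cn(Cc4cccc([N+](=O)[O-])c4)nn3)ccc12` stands at the weak end of what has been measured. In a functional assay on SW480 cells (Homo sapiens) for cytotoxicity, read by MTT assay, with a stated time of 48 h (a higher number here means a weaker inhibitor, a lower number a stronger inhibitor), compound 2 gives only a limit, > 100000 nM, and no number. That limit is the same one noted in the evidence (the limit of > 100000 nM in this assay, at which 1 of the 2 values shown sits). Compound 1 `O=c1ccoc2cc(OCc3cn(Cc4ccc(F)cc4)nn3)ccc12` gives 11200 nM in this assay. Among the measured compounds shown here, the only measured step is an at least 8.9-fold higher number from compound 1 to compound 2 (0.95 log units; beyond the scatter), so exchanging the 4-fluorophenyl for the 3-nitrophenyl pushed the number past the limit.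

Compound 3 `O=c1ccoc2cc(OCc3cn(Cc4ccc(Br)cc4)nn3)ccc12` has not yet been measured. It differs from compound 2 by 4-bromophenyl in place of 3-nitrophenyl on a saturated chain carbon bound to an aromatic nitrogen. This change removes the 3-nitrophenyl that went with the rise from compound 1 to compound 2 and brings back a halogen-bearing phenyl, as in compound 1. The step from compound 1 to compound 2 therefore bears directly on it, and its size suggests a drop in the number of at least that order, back toward the region of compound 1. Compound 3 is expected to give about 15000 nM in this assay, within 5000 nM to 60000 nM. The expected step is an at least 6.6-fold lower number from compound 2 to compound 3 (0.82 log units; beyond the scatter).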

Compound 3, half-maximal inhibitory concentration: 37500 nM
Compound 3: middle estimate off by 2.5-fold (0.40 log units), on the low side; the range from low to high includes it.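

In this assay, 4-bromophenyl in place of 3-nitrophenyl on a saturated chain carbon bound to an aromatic nitrogen gives an at least 2.6-fold lower number from compound 2 to compound 3 (0.42 log units; beyond the scatter), so a halogen-bearing phenyl at this place restores a measurable number without needing the fluoro group of compound 1. Compound 2 gives only a limit, so this step has a floor and no known size: the limit of > 100000 nM in this assay, at which 1 of the 3 values shown sits. The new comparison also shows that the two halogens are not interchangeable at this position: bromo in place of fluoro on an aromatic carbon gives a 3.3-fold higher number from compound 1 to compound 3 (0.52 log units; beyond the scatter), which leaves compound 1 the strongest of the three and shows that this position responds to the choice of halogen as well as to the loss of the nitro group.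

The compounds shown leave open whether the nitro group itself or its placement goes with the weak end, a question that a 4-nitrophenyl would address. They also leave open whether a 4-chlorophenyl would fall between compound 1 and compound 3, and what an amine on the phenyl would give.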